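A few compounds are considered here, and "the series" means these few. Any claim that something is new, unique, unknown or untested is made for them only; others in the source may bear on it.

In a functional assay on Vero cells (Chlorocebus sabaeus) for inhibition (on this read-out higher numbers stand for weaker inhibition and lower numbers for stronger inhibition), compound 1 `COc1cc(/C=C/C(=O)c2cccc(NC(=O)c3c(Cl)cccc3Cl)c2)ccc1O` gives 2.48 ug/mL, compound 2 `COc1cc(/C=C/C(=O)c2cccc(NC(=O)c3cccs3)c2)ccc1O` gives 3.98 ug/mL and compound 3 `CCCC(=O)Nc1cccc(C(=O)/C=C/c2ccc(O)c(OC)c2)c1` gives 2.04 ug/mL. Compound 3 therefore stands level with the other two, as its steps to both lie within the scatter. The next structure, compound 4 `COc1cc(/C=C/C(=O)c2cccc(NC(=O)c3ccccc3)c2)ccc1O`, has phenyl in place of propyl on a carbonyl carbon. Two measured steps change that same place, with propyl entering as a ring group leaves: a 1.2-fold lower number from compound 1 to compound 3 (0.08 log units; within the scatter), where 2,6-dichlorophenyl leaves, and a 2.0-fold lower number from compound 2 to compound 3 (0.29 log units; within the scatter), where thiophen-2-yl leaves. Both stay within the scatter, so no step beyond it is expected in this assay. The expected step is a 1.4-fold higher number from compound 3 to compound 4 (0.14 log units; within the scatter). The estimate for compound 4 is 2.8 ug/mL, with an expected range from 1.5 ug/mL to 5 ug/mL.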

Compound 4, half-maximal inhibitory concentration: 3.47 ug/mL
The estimate for compound 4 lay 1.2-fold (0.09 log units) below the measured number, and the stated range covers the measured number.
By their numbers in this assay, from the lowest: compounds 3, 1, 4 and 2 (each within the scatter of the next).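

In this assay, phenyl on this carbonyl carbon gives three more steps, all within the scatter: a 1.7-fold higher number from compound 3 to compound 4 (0.23 log units; within the scatter) and a 1.1-fold lower number from compound 2 to compound 4 (0.06 log units; within the scatter) and a 1.4-fold higher number from compound 1 to compound 4 (0.15 log units; within the scatter). Together with the earlier steps, this means that propyl, thiophen-2-yl, 2,6-dichlorophenyl and phenyl cannot be told apart at this position. A plain benzamido group therefore fits the same level as the chain and the other rings.

No measured evidence explains this flat picture. From the compounds shown here alone, whether an amine, a carboxylic acid or a longer chain at this carbonyl carbon would produce a step beyond the scatter remains open.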